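Indole acrylate series: acetyl to benzoyl on the vinyl sulfone

The source may report more compounds than this note shows. Statements on the series, on what has been measured and on what is new or still open speak of the compounds shown alone.

Measured so far:
- compound 1, `CCOC(=O)C(=Cc1c(-c2ccccc2)[nH]c2ccccc12)C(=O)OCC`, 3800 nM
- compound 2, `CC(=O)/C(=C\c1c(-c2ccccc2)[nH]c2ccccc12)S(=O)(=O)c1ccccc1`, 1100 nM

In a functional assay on NCI-H460 cells (Homo sapiens) for inhibition, read by sulforhodamine B assay, with a stated time of 48 h (on this read-out lower numbers stand for stronger inhibition of growth and higher numbers for weaker inhibition of growth), compound 2 stands at the lower of the two numbers; compound 1 sits higher, beyond the scatter. Compound 3, `O=C(/C(=C\c1c(-c2ccccc2)[nH]c2ccccc12)S(=O)(=O)c1ccccc1)c1ccccc1`, is not yet measured. It differs from compound 2 by phenyl in place of methyl on a carbonyl carbon. Going by the values given here, no measured pair shows this change, so only a small step is expected from compound 2 to compound 3, a 1.4-fold lower number from compound 2 to compound 3 (0.14 log units; within the scatter), within or near the scatter. Compound 3 is therefore estimated at 800 nM, with a range from 250 nM to 3000 nM.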

Compound 3, concentration for 50% growth inhibition: 5900 nM
Beside the measured number, compound 3's estimate is 7.4-fold (0.87 log units) below it, and the stated range ends below it.
By their numbers in this assay, from the lowest: compound 2; then compounds 1 and 3 (each within the scatter of the next).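

Under this assay phenyl in place of methyl on a carbonyl carbon gives a 5.4-fold higher number from compound 2 to compound 3 (0.73 log units; beyond the scatter) and so shows that this position is sensitive to the change, with benzoyl going with weaker inhibition of growth than acetyl. Going by these compounds alone, this single pair is the only reading of the position, so no trend across groups can be drawn from it. No measurement shown here explains the step.

As far as these compounds go, it remains open whether an ethyl chain on the carbonyl carbon stays close to compound 2 or moves toward compound 3. From the compounds shown here alone, the effect of an amine on the phenyl ring also remains open.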